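A Second Chloro Added to the Benzylamide Ring

A few compounds are considered here, and "the series" means these few. Any claim that something is new, unique, unknown or untested is made for them only; others in the source may bear on it.

Measured compounds:
compound 1 `CC(C)Cc1ccc(C(C)C(=O)NCc2ccc(Cl)cc2)cc1`: 27000 nM
compound 2 `CC(C)Cc1ccc(C(C)C(=O)NCc2ccc(C(F)(F)F)cc2)cc1`: 51000 nM

In an assay on brain for inhibition of Fatty-acid amide hydrolase 1 (Rattus norvegicus), read by scintillation counting, with a stated time of 10 min (a lower number here means a stronger inhibitor, a higher number a weaker inhibitor), compound 1 gives 27000 nM, the lowest of the two numbers. Compound 2 sits close by, and the step of a 1.9-fold higher number from compound 1 to compound 2 (0.28 log units; within the scatter) is within the scatter. Compound 3 `CC(C)Cc1ccc(C(C)C(=O)NCc2ccc(Cl)c(Cl)c2)cc1` differs from compound 1 by chloro in place of hydrogen on an aromatic carbon. Among the measured compounds shown here, no measured step speaks to this change directly, and the one step that is known was small. The expectation is therefore a step of a 1.4-fold lower number from compound 1 to compound 3 (0.13 log units; within the scatter) in this assay, hardly beyond the scatter. Compound 3 is expected to give 20000 nM, in a range from 7000 nM to 60000 nM.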

Compound 3, half-maximal inhibitory concentration: 36000 nM
Compound 3: middle estimate off by 1.8-fold (0.26 log units), on the low side; the range from low to high includes it.
By their numbers in this assay, from the lowest: compounds 1, 3 and 2 (each within the scatter of the next).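

Going from the 4-chlorophenyl to the 3,4-dichlorophenyl group, with the new chloro ortho to a chloro group, gives a step in this assay of a 1.3-fold higher number from compound 1 to compound 3 (0.12 log units; within the scatter). So this aromatic carbon carries a second chloro without a difference that can be told from the scatter, and this is the first direct reading of a change at this position. Nothing at hand explains this result. As far as these compounds go, whether an amine or a carboxylic acid on this same carbon would stand apart from compound 1 remains open.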